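The source may report more compounds than this note shows. Statements on the series, on what has been measured and on what is new or still open speak of the compounds shown alone.

Measured so far in an ADME assay on microsomes from liver (Rattus norvegicus, strain Wistar) for metabolic stability, tested at 2.5 uM; on this read-out higher numbers stand for fast clearance and lower numbers for slow clearance:

compound 1 `Clc1ccc(-c2ccc(Cn3nnc4ccccc43)cn2)cc1`: 1 mL/min/g
compound 2 `Brc1cccc2c1nnn2Cc1ccccc1`: 2 mL/min/g
compound 3 `Fc1ccccc1Cn1nnc2c(Br)cccc21`: 1.8 mL/min/g

In this assay compound 3 stands second highest of the three numbers, and all three lie within the scatter of one another, so no order among them can be claimed. For the measured compounds named here, the one measured step, a 1.1-fold lower number from compound 2 to compound 3 (0.05 log units; within the scatter), is within the scatter. Compound 4 `Fc1cc(Cl)ccc1Cn1nnc2c(Br)cccc21` differs from compound 3 in one place: chloro in place of hydrogen on an aromatic carbon. Going by the values given here, no measured step concerns a chloro group entering, so the step of compound 2 to compound 3 bears on it only by showing that a small change on this ring left the number essentially where it was. For compound 4 the expected outcome is a 1.1-fold higher number from compound 3 to compound 4 (0.05 log units; within the scatter), a step within the scatter. The estimate for compound 4 is 2 mL/min/g, with a range from 1 mL/min/g to 4 mL/min/g.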

Compound 4, intrinsic clearance in a liver preparation (reported as CLH), per the amount of preparation that the assay uses: 3.8 mL/min/g
Compound 4: the middle estimate sits 1.9-fold (0.28 log units) below what was measured; low and high end bracket the measured number.
By their numbers in this assay, from the lowest: compounds 1, 3, 2 and 4 (each within the scatter of the next, the first and the last beyond it).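

Chloro in place of hydrogen on this aromatic carbon, meta to a fluoro group and para to a large group, gives a 2.1-fold higher number from compound 3 to compound 4 (0.32 log units; beyond the scatter) in this assay. Among the steps shown, this is the only one beyond the scatter, so a single added chlorine atom at this place can shift the number, though modestly. No measurement shown offers a reason for this shift.

Going by these compounds, whether the shift is specific to chloro remains open, since no other group at this place, such as methyl, methoxy or an amine, appears here. On these data alone, the effect of chloro without the fluoro group also remains open.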